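Ring methyl step carried from one core to another

The source may report more compounds than this note shows. Statements on the series, on what has been measured and on what is new or still open speak of the compounds shown alone.

Compound 1 `COCn1c(CC(COCc2ccccc2)COCc2ccccc2)cc(=O)[nH]c1=O` and compound 2 `COCn1c(CC(COCc2ccccc2)COCc2ccccc2)c(C)c(=O)[nH]c1=O` share one core; compound 3 `C[Si](C)(C)CCOCn1c(CC(O)CO)cc(=O)[nH]c1=O` and the still unmeasured compound 4 `Cc1c(CC(O)CO)n(COCC[Si](C)(C)C)c(=O)[nH]c1=O` share another, and the difference between the two cores is not broken down here. In a functional assay on MCF7 cells (Homo sapiens) for antiproliferative activity, read by MTT assay, with a stated time of 72 h (on this read-out higher numbers stand for weaker inhibition and lower numbers for stronger inhibition), compound 1 reports only a limit, > 100000 nM, not a number. The change from compound 1 to compound 2 is methyl in place of hydrogen on an aromatic carbon. In this assay compound 2 gives 72600 nM. The resulting step is an at least 1.3-fold lower number from compound 1 to compound 2 (0.13 log units; that floor lies within the scatter); it is counted against a limit, as the limit of > 100000 nM in this assay, at which 2 of the 3 values shown sit, records, so only its floor is known and that floor lies within the scatter.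

In this assay compound 3 also reports only a limit, > 100000 nM. Compound 4 carries the same kind of change, (methyl in place of hydrogen on an aromatic carbon). The surroundings of the place are not identical: in compound 2 the methyl sits ortho to a large group and meta to a methoxymethyl group (3 heavy atoms), whereas in compound 4 it sits ortho to a 2,3-dihydroxypropyl group (5 heavy atoms) and meta to a group of 8 heavy atoms.

The expectation rests on the step of an at least 1.3-fold lower number from compound 1 to compound 2 (0.13 log units; that floor lies within the scatter), of which only the floor is known. The step estimated here is a number no higher from compound 3 to compound 4 (the limit leaves the size open). Compound 4 is therefore expected at 100000 nM, with a range from 40000 nM to 250000 nM, and a fair chance that it too returns only a limit.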

Compound 4, half-maximal inhibitory concentration: > 100000 nM
Compound 4 ended at the assay's limit; the forecaster's own chance of this, stated with the estimate: 55%; the middle value sits exactly at the limit.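

In this assay, compound 3 and compound 4 both report a limit and not a number, so no step can be read between them, because the result for each compound is this limit: the limit of > 100000 nM in this assay, at which 3 of the 4 values shown sit.

The compounds shown leave open how large the change from methyl in place of hydrogen on an aromatic carbon is on either core, as only compound 2 gives a number, 72600 nM.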